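The compounds below may be only part of what the source reports. "The series", "measured", "known", "first", "only" and "open" are said of these compounds alone.

Measured so far:
compound 1, `COc1ccc(C(=O)c2ccc3c(ccn3Cc3ccc(C(=O)NO)cc3)c2)cc1OC` — 756 nM
compound 2, `COc1cc(C(=O)c2ccc3c(ccn3S(=O)(=O)c3cccc(/C=C/C(=O)NO)c3)c2)cc(OC)c1OC` — 1260 nM

Both compounds were measured in an assay on isolated protein for inhibition of histone deacetylase 8 (Homo sapiens); a lower number here means a stronger inhibitor, a higher number a weaker inhibitor. Compound 1 gives the lower of the two numbers; the nearest neighbour, compound 2, sits a little higher, but the gap between the two lies within the scatter of the assay, so the two cannot be ordered on these data. Compound 2 also differs from compound 1 in several places at once, so nothing can be read from the pair about any single change.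

Compound 3, `Cc1ccc(C(=O)c2ccc3c(ccn3Cc3ccc(C(=O)NO)cc3)c2)cc1`, has not yet been measured. Its difference from compound 1 is 4-methylphenyl in place of 3,4-dimethoxyphenyl on a carbonyl carbon. Within the data shown here, no pair of measured compounds separated by a single change exists, so the step expected here rests on the structures alone. The change is confined to the aryl group on the carbonyl carbon and leaves the shared core untouched; the step is expected to be small, in either direction, most likely not beyond the scatter. The step from compound 1 to compound 3 is estimated at a 1.2-fold higher number from compound 1 to compound 3 (0.08 log units; within the scatter). Compound 3 is therefore expected to give about 900 nM, with a likely range from 350 nM to 2500 nM.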

Compound 3, half-maximal inhibitory concentration: 1490 nM
The estimate for compound 3 lay 1.7-fold (0.22 log units) below the measured number; the measured number falls inside the stated range.
By their numbers in this assay, from the lowest: compounds 1, 2 and 3 (each within the scatter of the next).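

Among these compounds, replacing 3,4-dimethoxyphenyl with 4-methylphenyl on a carbonyl carbon gives the first single-change step: a 2.0-fold higher number from compound 1 to compound 3 (0.29 log units; within the scatter) in this assay, so compound 1 and compound 3 cannot be ordered. The exchange takes the aryl group from 2 hydrogen-bond acceptors to 0 and from 10 heavy atoms to 7, yet the two numbers remain within the scatter of each other, so these data give no sign that the two methoxy groups are needed for a measurable number in this assay. No measurement bears on why this step has the size it has.

As far as these compounds go, whether any replacement at this place can move the number beyond the scatter remains open: an aryl group bearing an amine or a carboxylic acid, a phenyl group with no substituent, or a saturated cyclohexyl group in place of the aryl ring would test this. Steps to compound 2 cannot be read, since it differs from compound 1 and compound 3 in several places at once, which leaves the contribution of each of those differences unresolved.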